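The source may report more compounds than this note shows. Statements on the series, on what has been measured and on what is new or still open speak of the compounds shown alone.

Compound 1 `COc1ccc(N2CCN(C(=S)SCc3ccc(C(=O)Nc4ccccc4N)cc3)CC2)cc1` gives 39.4% in a functional assay on HeLa cells (Homo sapiens) for antiproliferative activity, read by CCK-8 assay, with a stated time of 72 h, tested at 2 uM; on this read-out lower numbers stand for a weaker effect and higher numbers for a stronger effect at the one concentration tested. Compound 2 `Nc1ccccc1NC(=O)c1ccc(CSC(=S)N2CCc3cc(Cl)ccc32)cc1` gives 40.1%. Compound 3 `N#Cc1ccc(N2CCN(C(=S)SCc3ccc(C(=O)Nc4ccccc4N)cc3)CC2)cc1` gives 71.6%.

Compound 2 and compound 1 thus lie within the scatter of each other, while compound 3 stands higher than both by a margin beyond the scatter. Compound 4 `CC1CCN(C(=S)SCc2ccc(C(=O)Nc3ccccc3N)cc2)CC1` arises from compound 2 by 4-methylpiperidin-1-yl in place of 5-chloro-2,3-dihydro-1H-indol-1-yl on a thiocarbonyl carbon. For the measured compounds named here, the only measured step, a number 32.2 percentage points higher from compound 1 to compound 3 (beyond the scatter), alters a substituent on an aromatic carbon elsewhere in the shared core, so it does not bear directly on this change. Compound 1 and compound 2 carry different amines on the thiocarbonyl carbon and yet sit within the scatter of each other, which hints that such exchanges matter little. Compound 4 is therefore estimated at 40%, ranging from 22% to 58%. The expected step, a number 0.1 percentage points lower from compound 2 to compound 4 (within the scatter), is not expected to exceed the scatter.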

Compound 4, a percentage reported as inhibition, at one concentration (the size of the read-out at that concentration, not a potency): 46.8%
Beside the measured number, compound 4's estimate is 6.8 percentage points below it; low and high end bracket the measured number.
By their numbers in this assay, from the lowest: compounds 1, 2 and 4 (each within the scatter of the next); then compound 3.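

For the compounds shown here, replacing the group on the thiocarbonyl carbon gives a number 6.7 percentage points higher from compound 2 to compound 4 (within the scatter) and so offers the first direct reading at this position. The six-membered aromatic ring of carbon only and the chlorine of 5-chloro-2,3-dihydro-1H-indol-1-yl can give way to 4-methylpiperidin-1-yl without a shift beyond the scatter. No measurement on hand explains this outcome.

From the compounds shown here alone, whether morpholin-4-yl or an open-chain diethylamino group on this carbon would stay within the scatter of these two compounds remains open. So does how either group would compare with the piperazine-bearing compound 3 at 71.6% in this assay.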